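Dropping One Chloro Group From Compound 1

This account rests on a few compounds, and the source may have more. Where it says the series, first, only, none or still open, it means among the compounds named here.

Compound 1 `ClCc1cccc(Cn2cnc3c(Cl)nc(Cl)nc32)c1` was tested in a functional assay on A549 cells (Homo sapiens) for cytotoxicity, read by sulforhodamine B assay, with a stated time of 48 h (on this read-out higher numbers stand for lower toxicity in this test and lower numbers for higher toxicity in this test), where compound 1 gives 52500 nM. Among the measured compounds shown here, this is the only single number in the set. For compound 2 `ClCc1ccccc1Cn1cnc2nc(Cl)nc(Cl)c21` this assay records only a limit, > 100000 nM, and not a number. Compound 3 `ClCc1ccccc1Cn1cnc2c(Cl)nc(Cl)nc21` has no result in this assay, its entry reading "not determined" (no result reported). For the measured compounds named here, compound 1 thus stands as the sole compound with a definite value, with one further compound at a limit and one without any result; the remaining entry is the limit of > 100000 nM in this assay, at which 1 of the 3 values shown sits, so the upper edge of the set is not a number.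

Going by the values given here, no two measured compounds differ in a single place, so no measured step is available to guide the next one.

Compound 4 `ClCc1cccc(Cn2cnc3c(Cl)ncnc32)c1` differs from compound 1 by hydrogen in place of chloro on an aromatic carbon: hydrogen enters where a chloro group leaves. Among the compounds with values here, with no measured step to lean on, the expected step in this assay is a 1.3-fold higher number from compound 1 to compound 4 (0.12 log units; within the scatter), small and most likely toward lower toxicity, and it may well stay within the scatter. Compound 4 is therefore expected to give about 70000 nM in this assay, with a range from 25000 nM to 200000 nM, and there is a fair chance that this assay reports only a limit for it.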

Compound 4, concentration lethal to 50% of the cells: 79400 nM
The estimate for compound 4 lay 1.1-fold (0.05 log units) below the measured number, and the stated range covers the measured number.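

The change at this position now has a measured size: in this assay the step is a 1.5-fold higher number from compound 1 to compound 4 (0.18 log units; within the scatter), so the read-out does not separate the two compounds. On the aromatic carbon between two ring nitrogen atoms, then, hydrogen can stand in place of chloro without a shift beyond the scatter, and compound 4 still gives a definite number rather than a limit. Among the compounds shown here, this is the first single-place comparison in the set, but it rests on one pair of compounds and supports no claim about why the number holds or about the chloro group that remains on the core.

An amine, a methoxy group or a methyl group at this carbon would show whether any replacement there can move the read-out beyond the scatter, and the compounds shown give no answer to that. The top of the range also remains undefined, as compound 2 carries a limit and not a number: the limit of > 100000 nM in this assay, at which 1 of the 4 values shown sits.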